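Replacing the cyano ester side chain of compound 3

The source may report more compounds than this note shows. Statements on the series, on what has been measured and on what is new or still open speak of the compounds shown alone.

Measured in a functional assay with Oryctolagus cuniculus as the target; on this read-out lower numbers stand for stronger inhibition and higher numbers for weaker inhibition:
- compound 1 `COc1ccc(-c2nc(CN)sc2-c2ccc(OC)cc2)cc1`: > 100 nM (a limit)
- compound 2 `COc1ccc(-c2nc(CNC(=O)NC(C)C)sc2-c2ccc(OC)cc2)cc1`: 42 nM
- compound 3 `CCOC(=O)/C(C#N)=C/c1nc(-c2ccc(OC)cc2)c(-c2ccc(OC)cc2)s1`: < 10 nM (a limit)

Compound 3 has the lowest number of the three, and its steps to both others lie beyond the scatter. For compound 3, < 10 nM is a limit and not a number.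

The next compound is compound 4 `COc1ccc(-c2nc(/C=C/C(=O)O)sc2-c2ccc(OC)cc2)cc1`. Its difference from compound 3 is 2-carboxyethenyl in place of 2-cyano-2-(ethoxycarbonyl)ethenyl on an aromatic carbon. In words, 2-carboxyethenyl stands in place of 2-cyano-2-(ethoxycarbonyl)ethenyl on an aromatic carbon.

Two measured steps change this same place: an at least 10-fold lower number from compound 1 to compound 3 (1.00 log units; beyond the scatter) and an at least 4.2-fold lower number from compound 2 to compound 3 (0.62 log units; beyond the scatter). The step of an at least 2.3-fold lower number from compound 1 to compound 2 (0.37 log units; beyond the scatter) changes an amine nitrogen instead, so it bears only indirectly. Among the measured compounds shown here, no measured compound carries 2-carboxyethenyl, and both steps at this place are bounds. A modest move to a higher number in this assay is therefore expected. The expected change is an at least 2.5-fold higher number from compound 3 to compound 4 (0.39 log units; beyond the scatter). Compound 4 is estimated at 25 nM, within an expected range from 4 nM to 150 nM.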

Compound 4, half-maximal inhibitory concentration: > 100 nM
Compound 4 gave a limit, no number; the forecaster's own chance of this, stated with the estimate: 35%; at least 4.0-fold (0.60 log units) between middle value and limit.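

In this assay, the change to 2-carboxyethenyl gives an at least 10-fold higher number from compound 3 to compound 4 (1.00 log units; beyond the scatter), so an ethenyl link on this aromatic carbon is not enough on its own to keep the low number of compound 3. The same side chain also compares poorly with the ((isopropylcarbamoyl)amino)methyl group, which has no ethenyl link, with an at least 2.3-fold higher number from compound 2 to compound 4 (0.37 log units; beyond the scatter). Compound 4 gives a limit, as does compound 1, so the step between those two cannot be read: the limit of > 100 nM in this assay, at which 2 of the 4 values shown sit.

Compound 4 loses the nitrile and the ethyl ester together, and a 2-cyanoethenyl group or a 2-(ethoxycarbonyl)ethenyl group would be needed to separate their parts in the result. As far as these compounds go, compound 3 gives < 10 nM, which is a limit, so the full size of these steps also stays open.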